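Swapping ethynyl for benzofuranyl on a nucleoside core

The source may report more compounds than this note shows. Statements on the series, on what has been measured and on what is new or still open speak of the compounds shown alone.

For the measured compounds named here, compound 1 `C#Cc1cn([C@@H]2O[C@H](CO)[C@@H](O)[C@H]2O)c2ncnc(N(C)C)c12` is the only compound with a full number here. In a functional assay on CCRF-CEM cells (Homo sapiens), read by MTT assay, with a stated time of 72 h (a higher number here means a weaker inhibitor, a lower number a stronger inhibitor), compound 1 gives 90 nM. Compound 2 `C#Cc1cn([C@@H]2O[C@H](CO)[C@@H](O)[C@H]2O)c2ncnc(OC)c12` reaches only the limit of > 20000 nM in this assay. Going by the values given here, the step of an at least 220-fold higher number from compound 1 to compound 2 (2.34 log units; beyond the scatter) is the one measured step, and it touches a different place than the change now at hand. Compound 3 `CN(C)c1ncnc2c1c(-c1cc3ccccc3o1)cn2[C@@H]1O[C@H](CO)[C@@H](O)[C@H]1O` differs from compound 1 by 1-benzofuran-2-yl in place of ethynyl on an aromatic carbon. Among the compounds with values here, no measured step bears on this change, so the expectation rests on compound 1 alone: a modest loss, a 3.3-fold higher number from compound 1 to compound 3 (0.52 log units; beyond the scatter), is estimated. Compound 3 is expected to give 300 nM in this assay, within 50 nM to 3000 nM.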

Compound 3, half-maximal inhibitory concentration: > 20000 nM
Compound 3: no number, only a limit (the forecaster's own chance of this, stated with the estimate: 10%); middle value at least 66-fold (1.82 log units) away from the limit.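

In this assay the change from ethynyl to 1-benzofuran-2-yl gives an at least 220-fold higher number from compound 1 to compound 3 (2.34 log units; beyond the scatter), so the aromatic carbon that the earlier step left untouched also matters for this activity. Compound 3 gives > 20000 nM as a limit of the assay and not a number. The size of this step is therefore only a bound: the limit of > 20000 nM in this assay, at which 2 of the 3 values shown sit.

From the compounds shown here alone, compound 1 gives 90 nM with ethynyl on this carbon, and how a methyl group or a furan-2-yl group there would compare stays open.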